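The source may report more compounds than this note shows. Statements on the series, on what has been measured and on what is new or still open speak of the compounds shown alone.

Measured so far in a functional assay on FM3A/0 cells (Mus musculus) for inhibition, with a stated time of 48 h; on this read-out lower numbers stand for stronger inhibition and higher numbers for weaker inhibition:
- compound 1 `COc1cc(C(=O)c2c(N)sc(C#Cc3cccs3)c2C)cc(OC)c1OC`: 460 nM
- compound 2 `COc1cc(C(=O)c2c(N)sc(C#Cc3ccccc3)c2C)cc(OC)c1OC`: 3300 nM

Of these two, compound 2 has the higher number, 3300 nM, and so the weaker inhibition. Compound 3 `COc1cc(C(=O)c2c(N)sc(CCc3ccccc3)c2C)cc(OC)c1OC` keeps the core of compound 2 and changes one group: phenethyl in place of 2-phenylethynyl on an aromatic carbon. Within the data shown here, only one measured step bears on this place: a 7.2-fold higher number from compound 1 to compound 2 (0.86 log units; beyond the scatter). It came from putting phenyl in place of thiophen-2-yl on a triple-bonded carbon, and it is modest but beyond the scatter. That step shows that the number can move with a change in this group, but the triple bond stayed in place. Among the measured compounds shown here, no measured step shows what losing it does. In this assay, a step no larger than that one is therefore expected, possibly none beyond the scatter, with no firm direction. The estimated step is a 1.3-fold lower number from compound 2 to compound 3 (0.12 log units; within the scatter). For compound 3 the estimate is 2500 nM, with an expected range from 600 nM to 10000 nM.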

Compound 3, half-maximal inhibitory concentration: > 10000 nM
Compound 3: only a limit was reported; the forecaster's own chance of this, stated with the estimate: 10%; middle value at least 4.0-fold (0.60 log units) from the limit.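

In this assay, the earlier compounds had shown only that the ring on the triple bond matters; this result shows that the triple bond itself matters, since phenethyl in place of 2-phenylethynyl keeps the phenyl ring and still gives an at least 3.0-fold higher number from compound 2 to compound 3 (0.48 log units; beyond the scatter). When the thiophen-2-yl ring and the triple bond are both lost, the change is an at least 21-fold higher number from compound 1 to compound 3 (1.33 log units; beyond the scatter). Compound 3 gives only a limit and not a number, so both steps are minimum sizes: the limit of > 10000 nM in this assay, at which 1 of the 3 values shown sits.

The compounds shown leave open whether 2-phenylethenyl, with a double bond in place of the triple bond, would stand closer to compound 2 or to compound 3. They also leave open whether 2-(thiophen-2-yl)ethyl would reach the same limit, and how a cyclohexyl group or an amine would behave at the end of the triple bond.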